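Nitrogen side-chain change from compound 3 to compound 4

This account rests on a few compounds, and the source may have more. Where it says the series, first, only, none or still open, it means among the compounds named here.

Measured in an ADME assay on Huh-7 cells (Homo sapiens) for cytotoxicity, with a stated time of 72 h; a lower number here means that less compound is tolerated, a higher number that more compound is tolerated:
compound 1 `CC(C)CCn1nc(-c2cccs2)c(O)c(C2=NS(=O)(=O)c3cc(CS(C)(=O)=O)ccc3N2)c1=O`: > 33000 nM
compound 2 `C/C(=C\c1nn(CCC(C)C)c(=O)c(C2=NS(=O)(=O)c3cc(NS(C)(=O)=O)ccc3N2)c1O)C(F)(F)F`: > 33000 nM
compound 3 `CCC(C)n1nc(-c2cccs2)c(O)c(C2=NS(=O)(=O)c3cc(NS(C)(=O)=O)ccc3N2)c1=O`: > 33000 nM

All three entries are limits and not numbers. Compound 3 gives > 33000 nM, which is a limit. Among the measured compounds shown here, the series so far offers no numerical spread, and every compound sits at the limit of > 33000 nM in this assay, at which 3 of the 3 values shown sit.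

Compound 4 `CS(=O)(=O)Nc1ccc2c(c1)S(=O)(=O)N=C(c1c(O)c(-c3cccs3)nn(CCC3CCCCC3)c1=O)N2` keeps the core of compound 3 and its thiophen-2-yl group, with 2-cyclohexylethyl in place of sec-butyl on an aromatic nitrogen. For the measured compounds named here, no pair of measured compounds differs in one place, so this change has no direct precedent.

In this assay a small move at most is expected, in the direction of less compound tolerated, and a further report of the limit is likely. The estimated change is an at least 1.1-fold lower number from compound 3 to compound 4 (0.04 log units; that floor lies within the scatter). That expectation rests on compound 3 and its limit > 33000 nM. For compound 4 the expected value is 30000 nM, with an estimated range of 12000 nM to 50000 nM.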

Compound 4, half-maximal cytotoxic concentration: > 17000 nM
Compound 4: only a limit was reported (the forecaster's own chance of this, stated with the estimate: 65%); the middle value does not contradict the limit.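

In this assay, among the compounds shown here, compound 3 and compound 4 are both reported only as limits, and no step between them can be read. Left open is whether 2-cyclohexylethyl in place of sec-butyl on an aromatic nitrogen shifts the tolerated concentration at all: every compound shown carries a limit, not a number.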